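The source may report more compounds than this note shows. Statements on the series, on what has been measured and on what is new or still open speak of the compounds shown alone.

In a functional assay on HeLa cells (Homo sapiens) for antiproliferative activity, read by MTT assay, with a stated time of 48 h (on this read-out higher numbers stand for weaker inhibition and lower numbers for stronger inhibition), compound 3 `CN(C)CCCCn1c(N)c(C#N)c2nc(C#N)c(C#N)nc21` gives > 50000 nM, which is a limit of the assay and not a number. Going by the values given here, it is the only such reading, as the limit of > 50000 nM in this assay, at which 1 of the 3 values shown sits, shows.

Compound 4 `CN(C)CCCCn1c(N)c(-c2nc3ccccc3n2C)c2nc(C#N)c(C#N)nc21` keeps the 4-(dimethylamino)butyl group and carries 1-methyl-1H-benzimidazol-2-yl in place of cyano on an aromatic carbon, next to the ring atom that bears an amino group: 1-methyl-1H-benzimidazol-2-yl in place of cyano on an aromatic carbon.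

Among the compounds with values here, no measured step covers this exchange. The nearest evidence comes from two compounds that hold the entering group without its methyl. Compound 1 `CCN(CC)CCCn1c(N)c(-c2nc3ccccc3[nH]2)c2nc(C#N)c(C#N)nc21` gives 3150 nM, and compound 2 `CCN(CC)CCCCn1c(N)c(-c2nc3ccccc3[nH]2)c2nc(C#N)c(C#N)nc21` gives 10100 nM. Within the data shown here, the one measured step, a 3.2-fold higher number from compound 1 to compound 2 (0.51 log units; beyond the scatter), is modest, lies beyond the scatter and concerns the chain, not this aromatic carbon. Compound 4 shares the chain length of compound 2, which reads 10100 nM, so a value in that region is expected.

The expected change is an at least 4.1-fold lower number from compound 3 to compound 4 (0.61 log units; beyond the scatter), towards stronger inhibition in this assay. For compound 4 the estimated value is 12000 nM, with an expected range of 4000 nM to 40000 nM.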

Compound 4, half-maximal inhibitory concentration: 460 nM
Beside the measured number, compound 4's estimate is 26-fold (1.42 log units) above it; measured number outside the range, below it.
By their numbers in this assay, from the lowest: compound 4; then compound 1; then compound 2. At a limit, above all of these: compound 3.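

On the aromatic carbon next to the ring atom that bears an amino group, with the 4-(dimethylamino)butyl group held, 1-methyl-1H-benzimidazol-2-yl in place of cyano gives an at least 100-fold lower number from compound 3 to compound 4 (2.03 log units; beyond the scatter) in this assay. Going by these compounds alone, this large step is the first measured exchange at this carbon, and it shows that the group here matters to the read-out, whereas the only earlier step, a 3.2-fold higher number from compound 1 to compound 2 (0.51 log units; beyond the scatter), is modest and concerns the chain. The size of the new step is a bound and not an exact figure, since compound 3 stands at a limit of the assay: the limit of > 50000 nM in this assay, at which 1 of the 4 values shown sits.

Compound 2 and compound 4 differ in more than one place, so the effect of the methyl on 1-methyl-1H-benzimidazol-2-yl cannot be separated from that of the amine at the end of the chain. From the compounds shown here alone, how a phenyl ring or a carboxamide would read on this carbon remains open.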